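The source may report more compounds than this note shows. Statements on the series, on what has been measured and on what is new or still open speak of the compounds shown alone.

Working notes on the series. In an assay for binding affinity to Alpha-1B adrenergic receptor (Homo sapiens) (on this read-out lower numbers stand for stronger inhibition and higher numbers for weaker inhibition), compound 2 `CN(C)CCn1nc(Cc2ccc(Cl)cc2)c2ccccc2c1=O` gives 200 nM. Going by the values given here, the only other measured member, compound 1 `O=c1c2ccccc2c(Cc2ccc(Cl)cc2)nn1CCNCCCCc1ccc(OCCCN2CCCCCC2)cc1`, gives 316 nM in this assay. Among the compounds with values here, of the two numbers, that of compound 2 sits at the lower end, yet its distance to compound 1 stays within the usual scatter, so the two compounds cannot be told apart on this read-out, and no step between measured compounds is available as a guide.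

The next compound, compound 3 `CN1CCCCC(n2nc(Cc3ccc(Cl)cc3)c3ccccc3c2=O)C1`, keeps the shared core and the 4-chlorobenzyl group and changes only the substituent on the aromatic nitrogen: 1-methylazepan-3-yl in place of 2-(dimethylamino)ethyl on an aromatic nitrogen. The open chain is thus replaced by a ring that carries the same count of acceptors and no donor, with the nitrogen still present as a 1-methylazepan-3-yl. With nothing measured across a comparable change, the expectation for this assay is a step from compound 2 to compound 3 of about a 1.3-fold higher number from compound 2 to compound 3 (0.10 log units; within the scatter), that is, no move beyond the scatter in either direction. Compound 3 is therefore estimated at 250 nM, with a range from 80 nM to 800 nM.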

Compound 3, inhibition constant: 158 nM
The estimate for compound 3 lay 1.6-fold (0.20 log units) above the measured number; measured number inside the range.
By their numbers in this assay, from the lowest: compounds 3, 2 and 1 (each within the scatter of the next).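

Going by these compounds alone, this is the first step that can be read at the substituent on the aromatic nitrogen: in this assay the exchange of the open 2-(dimethylamino)ethyl chain for 1-methylazepan-3-yl gives a 1.3-fold lower number from compound 2 to compound 3 (0.10 log units; within the scatter) and stays within the scatter, so compound 2 and compound 3 cannot be told apart on this read-out. The position thus tolerates the entering group, with its seven-membered non-aromatic ring and 8 heavy atoms against 5 in the leaving group, with no difference that this read-out can resolve, while the counts of hydrogen-bond donors and acceptors stay the same. Nothing at hand bears on why the two groups read alike.

The compounds shown leave open whether this tolerance extends to a smaller ring such as 1-methylpiperidin-3-yl, or to an azepane carrying a hydrogen in place of the methyl group on its nitrogen. They also leave open whether the same exchange would read alike with an unsubstituted benzyl group in place of the 4-chlorobenzyl group on the shared core.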